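This account rests on a few compounds, and the source may have more. Where it says the series, first, only, none or still open, it means among the compounds named here.

Compound 1 `CCN1CCN(c2cc(C)c3cc(NC(=O)c4cc(Cl)cc(Cl)c4)ccc3n2)CC1` gives 2660 nM in a functional assay on SK-BR-3 cells (Homo sapiens) for antiproliferative activity, read by MTT assay, with a stated time of 72 h; a lower number here means a stronger inhibitor, a higher number a weaker inhibitor.
Compound 2 `Cc1cc(NCCN2CCCC2)nc2ccc(NC(=O)c3ccc(Cl)c(Cl)c3)cc12` gives 9530 nM in this assay.
Compound 3 `Cc1cc(N2CCN(C)CC2)nc2ccc(NC(=O)c3ccc(Cl)c(Cl)c3)cc12` gives 6320 nM in this assay.

Of these three, compound 1 stands lowest in this assay; compound 3 comes nearest to it and compound 2 lies furthest from it, both gaps being beyond the scatter. Among the measured compounds shown here, the only single-site step among the measured compounds is a 1.5-fold lower number from compound 2 to compound 3 (0.18 log units; within the scatter), a change at the aromatic carbon of the shared core that lies within the scatter.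

Compound 4 `CCN1CCN(c2cc(C)c3cc(NC(=O)c4cc5ccccc5[nH]4)ccc3n2)CC1` differs from compound 1 at a different place: 1H-indol-2-yl in place of 3,5-dichlorophenyl on a carbonyl carbon. For the measured compounds named here, the step from compound 2 to compound 3 touches the other end of the molecule, so no measured step speaks to this exchange on the carbonyl carbon. Without a comparable step, the expectation can only rest on where compound 1 already stands. Compound 4 is therefore expected to lie near compound 1, with a wide range, at about 3000 nM (between 800 nM and 12000 nM), an expected step of a 1.1-fold higher number from compound 1 to compound 4 (0.05 log units; within the scatter).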

Compound 4, half-maximal inhibitory concentration: 2550 nM
Beside the measured number, compound 4's estimate is 1.2-fold (0.07 log units) above it, within the range that was stated.
By their numbers in this assay, from the lowest: compounds 4 and 1 (each within the scatter of the next); then compounds 3 and 2 (each within the scatter of the next).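

On the carbonyl carbon, 1H-indol-2-yl can take the place of 3,5-dichlorophenyl with no difference that this assay can separate, the step being a 1.0-fold lower number from compound 1 to compound 4 (0.02 log units; within the scatter) and lying within the scatter. Among the compounds shown here, this is the first measured step at this end of the molecule, and it shows that two quite different groups read alike here: one carries two chlorine atoms on a single six-membered ring, while the other adds a five-membered ring with a nitrogen and a hydrogen-bond donor. Nothing available explains why these two groups read alike.

On these data alone, it remains open whether any ring is needed on this carbonyl carbon, as a simple methyl group or a longer alkyl chain there would show. Also open, as far as these compounds go, is whether the hydrogen on the ring nitrogen counts, which 1-methyl-1H-indol-2-yl would test.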